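The source may hold more compounds than are shown below. What is called first, only, known or untested is meant among the compounds shown, and "the series" means these compounds.

Values in a functional assay on NCI-H460 cells (Homo sapiens) for inhibition, read by MTT assay, with a stated time of 48 h; a higher number here means a weaker inhibitor of growth, a lower number a stronger inhibitor of growth:
compound 1 `O=[N+]([O-])c1ccc(-c2cc(-c3ccccc3)n[nH]2)cc1`: 10200 nM
compound 2 `COc1ccc(-c2cc(-c3ccc([N+](=O)[O-])cc3)[nH]n2)cc1`: 18300 nM
compound 3 `Nc1ccc(-c2cc(-c3ccccc3)n[nH]2)cc1`: 26700 nM

Compound 3 gives the highest number of the three, but its gap to compound 2 is within the scatter, so the two cannot be told apart on these data. Against compound 1 the step is real: a 2.6-fold higher number from compound 1 to compound 3 (0.42 log units; beyond the scatter).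

Compound 4 `Nc1ccc(-c2cc(-c3ccc(C(F)(F)F)cc3)n[nH]2)cc1` differs from compound 3 in one place: trifluoromethyl in place of hydrogen on an aromatic carbon. Within the data shown here, the only measured step that bears on a substituent entering in place of hydrogen on an aromatic carbon of the shared core is the one with methoxy: a 1.8-fold higher number from compound 1 to compound 2 (0.25 log units; within the scatter). That step did not leave the scatter. Among the measured compounds shown here, no measured pair carries a trifluoromethyl group, so the series gives no direct precedent for it, and the amino group of compound 3 stays in place. As far as these compounds go, nothing here points to a step beyond the scatter in this assay for compound 4 in either direction; the range is kept wide, since the group is untested.

The estimate for compound 4 is 25000 nM, with a range from 9000 nM to 70000 nM. The step this estimate implies is expected to be a 1.1-fold lower number from compound 3 to compound 4 (0.03 log units; within the scatter).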

Compound 4, concentration for 50% growth inhibition: 21500 nM
Compound 4: the middle estimate sits 1.2-fold (0.07 log units) above what was measured; the range from low to high includes it.
By their numbers in this assay, from the lowest: compounds 1, 2, 4 and 3 (each within the scatter of the next, the first and the last beyond it).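

In this assay, trifluoromethyl on an aromatic carbon, para to a large group, gives a 1.2-fold lower number from compound 3 to compound 4 (0.09 log units; within the scatter), so the two compounds cannot be told apart and the amino series tolerates this group at this position without a measurable change. Among these compounds, this is a second substituent entering in place of hydrogen on an aromatic carbon that stays inside the scatter, after methoxy on the nitro compound with a 1.8-fold higher number from compound 1 to compound 2 (0.25 log units; within the scatter), and so far the only step beyond the scatter is the change from nitro to amino, a 2.6-fold higher number from compound 1 to compound 3 (0.42 log units; beyond the scatter). No measurement on hand bears on why the new group leaves the number unmoved.

As far as these compounds go, whether a group of another kind at this position, such as a carboxylic acid or a dimethylamine, would move the number beyond the scatter remains open. Among the compounds shown here, also open is whether trifluoromethyl gives the same result on compound 1, where nitro stands in place of the amino group, since the single step here was read with amino in place.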